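This account rests on a few compounds, and the source may have more. Where it says the series, first, only, none or still open, it means among the compounds named here.

Compound 1 `Cc1ccc2c(O)c(C(=O)OCc3ccccc3)cnc2n1` gives > 10000 nM in an assay for binding affinity to adenosine receptor A1 (Bos taurus) (a lower number here means a stronger inhibitor, a higher number a weaker inhibitor), a limit of the assay. Compound 2 `Cc1ccc2c(O)c(C(=O)NN3CCOCC3)cnc2n1` gives > 10000 nM in this assay, also a limit. Compound 3 `Cc1ccc2c(O)c(C(=O)NC3CCC(C)CC3)cnc2n1` gives 6000 nM in this assay.

Compound 1 and compound 2 sit at the limit of > 10000 nM in this assay, at which 2 of the 3 values shown sit. Among the compounds with values here, compound 3 thus holds the only number among the three. Compound 4 `Cc1ccc2c(O)c(C(=O)NCCC(C)C)cnc2n1` differs from compound 3 by isopentyl in place of 4-methylcyclohexyl on an amide-type nitrogen. Within the data shown here, one measured step touches the same amide nitrogen: an at least 1.6-fold lower number from compound 2 to compound 3 (0.22 log units; that floor lies within the scatter), which moved the value out of the limit. Among the measured compounds shown here, no measured step compares two alkyl groups at that position, so the size of a ring-to-chain exchange there is unknown. The step is expected to be a 1.1-fold higher number from compound 3 to compound 4 (0.03 log units; within the scatter), no more than scatter. Compound 4 is estimated at 6500 nM in this assay, between 2500 nM and 16000 nM.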

Compound 4, inhibition constant: > 10000 nM
Compound 4: no number, only a limit; the forecaster's own chance of this, stated with the estimate: 40%; middle value at least 1.5-fold (0.18 log units) from the limit.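

Within the data shown here, on the amide-type nitrogen, isopentyl in place of 4-methylcyclohexyl gives an at least 1.6-fold higher number from compound 3 to compound 4 (0.22 log units; that floor lies within the scatter), the first comparison of two alkyl groups at this position, so a floor this small does not establish that the ring matters. Compound 4 gives no number, only a limit: the limit of > 10000 nM in this assay, at which 3 of the 4 values shown sit.

The step from compound 2 to compound 4 cannot be read. The compounds shown leave open where the true value of compound 4 lies, and whether unsubstituted cyclohexyl, phenyl or a longer chain on this nitrogen would give a lower number than compound 3 in this assay.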